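The source may hold more compounds than are shown below. What is called first, only, known or untested is meant among the compounds shown, and "the series" means these compounds.

Measured in a functional assay on MDA-MB-231 cells (Homo sapiens) for antiproliferative activity, read by MTT assay, with a stated time of 48 h; on this read-out lower numbers stand for stronger inhibition of growth and higher numbers for weaker inhibition of growth:
- compound 1 `COc1cc(C2CC(c3ccccc3)=NN2C(=O)OCc2ccccc2)cc(OC)c1OC`: > 10000 nM, a limit
- compound 2 `COc1cccc(C2=NN(C(=O)OCc3ccccc3)C(c3cc(OC)c(OC)c(OC)c3)C2)c1`: > 10000 nM, a limit
- compound 3 `CCCOC(=O)N1N=C(c2cccc(O)c2)CC1c1cc(OC)c(OC)c(OC)c1`: 10000 nM

Going by the values given here, compound 3 gives the only actual number in this short series, 10000 nM. The other two results are limits, as the limit of > 10000 nM in this assay, at which 2 of the 3 values shown sit, shows.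

The next compound is compound 4 `COc1cc(C2CC(c3cccc(O)c3)=NN2C(=O)OCc2ccccc2)cc(OC)c1OC`. Its difference from compound 3 is phenyl in place of ethyl on a saturated chain carbon bound to an oxygen next to a carbonyl group. In words, this is phenyl in place of ethyl on a saturated chain carbon bound to an oxygen next to a carbonyl group, which also reads as propoxycarbonyl to benzyloxycarbonyl.

Among the compounds with values here, no measured step covers this change. Within the data shown here, the one step between measured compounds, a step that the two limits leave unreadable from compound 1 to compound 2, is a different change and gives no size to carry over. Among the measured compounds shown here, compounds 1 and 2 do share the benzyloxycarbonyl group with compound 4, and the only guide they offer is the limit of > 10000 nM in this assay, at which 2 of the 3 values shown sit. Compound 3, at 10000 nM, sets the starting point.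

In this assay, no shift beyond the usual scatter is expected, so the expected step is no change at the digits printed from compound 3 to compound 4 (within the scatter). A result reported only as a limit would be no surprise.

For compound 4 the estimated value is 10000 nM, with an expected range of 3000 nM to 20000 nM.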

Compound 4, concentration for 50% growth inhibition: > 10000 nM
Compound 4 gave a limit, no number; the forecaster's own chance of this, stated with the estimate: 50%; the middle value lies on the limit itself.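

In this assay, the change from propoxycarbonyl to benzyloxycarbonyl, with the hydroxy group kept on the aromatic ring, gives a number no lower from compound 3 to compound 4 (the limit leaves the size open). Going by these compounds alone, this is the first step with a readable direction, and it shows that phenyl in place of ethyl on this saturated chain carbon brings no lower number, although the size of the step stays open. The steps to compound 4 from compound 1 and from compound 2 cannot be read, so the hydroxy group and the methoxy group on the aromatic ring remain unranked when benzyloxycarbonyl is present, and the series now sits mostly at one limit: the limit of > 10000 nM in this assay, at which 3 of the 4 values shown sit.

Going by these compounds, how far compound 4 lies from compound 3 remains open, as does any ordering among the benzyloxycarbonyl compounds. The compounds shown also leave open whether a carboxylic acid or an amine on the phenyl of the benzyloxycarbonyl group, or a chain longer than propyl in the carbamate-type position's place of the benzyl, would bring a number below the limit.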